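A few compounds are considered here, and "the series" means these few. Any claim that something is new, unique, unknown or untested is made for them only; others in the source may bear on it.

Working notes on the series. Compound 1 `CC(C)COC(=O)N1CCN(C(=O)c2nc(Nc3cc(C4CC4)[nH]n3)c3cc(Cl)ccc3n2)C[C@H]1C` is the reference point for the step considered here; in an assay for inhibition of serine/threonine-protein kinase PAK 4 (Homo sapiens), read by FRET and Z'-LYTE, with a stated time of 60 min, tested at 5 uM, in the presence of a further agent that is not named here (a higher number here means a stronger effect of the compound at the concentration tested, a lower number a weaker effect), compound 1 gives 30.7%. Within the data shown here, its partner compound 2 `C[C@@H]1CN(C(=O)c2nc(Nc3cc(C4CC4)[nH]n3)c3cc(Cl)ccc3n2)CCN1C(=O)OCOC(=O)C(C)(C)C` gives 24.1% in this assay, and the only measured step, a number 6.6 percentage points lower from compound 1 to compound 2 (within the scatter), lies within the scatter, so the two numbers are not told apart by the data. Compound 1 thus stands as the higher of two figures that cannot be ordered with confidence.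

The unmeasured compound 3 `CC(C)OC(=O)N1CCN(C(=O)c2nc(Nc3cc(C4CC4)[nH]n3)c3cc(Cl)ccc3n2)C[C@H]1C` differs from compound 1 in one place: isopropyl in place of isobutyl on an oxygen next to a carbonyl group. Among the measured compounds shown here, the one step that bears on this change is the one at the same oxygen next to a carbonyl group, from compound 1 to compound 2, which moved the read-out by a number 6.6 percentage points lower from compound 1 to compound 2 (within the scatter) and stayed within the scatter. That step exchanged a larger group than the present one, yet showed no effect beyond the scatter, so for compound 3 no step beyond the scatter is expected in this assay, and the estimated step is a number 2.7 percentage points lower from compound 1 to compound 3 (within the scatter). For compound 3 the expected value is 28%, with the likely range from 15% to 42%.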

Compound 3, a percentage reported as inhibition, at one concentration (the size of the read-out at that concentration, not a potency): 75.8%
Estimate against measurement, compound 3: 47.8 percentage points below, and the stated range ends below it.
By their numbers in this assay, from the lowest: compounds 2 and 1 (each within the scatter of the next); then compound 3.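

In this assay, among these compounds, the group on an oxygen next to a carbonyl group turns out to matter: isopropyl in place of isobutyl, 3 heavy atoms for 4, gives a number 45.1 percentage points higher from compound 1 to compound 3 (beyond the scatter), whereas the one earlier exchange at this oxygen produced nothing beyond the scatter. Isopropyl in place of (((tert-butyl)carbonyl)oxy)methyl gives a number 51.7 percentage points higher from compound 2 to compound 3 (beyond the scatter), so among the three compounds isopropyl alone stands apart, while the two other groups at this oxygen cannot be told from each other. Nothing measured here accounts for so large a step from so small a change in the group.

From the compounds shown here alone, whether ethyl, methyl or cyclobutyl on this oxygen would hold the read-out near that of compound 3 remains open, so isopropyl cannot yet be called a narrow requirement rather than one member of a wider set of short groups. Going by these compounds, the read-out is also the size of the effect at one concentration and not a potency, so the gap in potency between compound 1 and compound 3 remains open as well.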